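This account rests on a few compounds, and the source may have more. Where it says the series, first, only, none or still open, it means among the compounds named here.

In a functional assay on MV4-11 cells (Homo sapiens) for antiproliferative activity, read by CellTiter-Glo, with a stated time of 72 h (on this read-out higher numbers stand for weaker inhibition and lower numbers for stronger inhibition), the measured compounds stand as follows:
compound 1 `CO[C@@H]1[C@H](N(C)c2ncc(-c3c[nH]c4ccc(F)cc34)s2)C[C@H]2O[C@]1(C)n1c3ccccc3c3c4c(c5c6cc(Cl)ccc6n2c5c31)C(=O)NC4` gives 320 nM;
compound 2 `CO[C@@H]1[C@H](N(C)c2ncc(-c3c[nH]c4ccc(Cl)cc34)s2)C[C@H]2O[C@]1(C)n1c3ccccc3c3c4c(c5c6cc(Cl)ccc6n2c5c31)C(=O)NC4` gives 590 nM;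
compound 3 `CO[C@@H]1[C@H](N(C)c2ncc(-c3c[nH]c4ccc(F)cc34)s2)C[C@H]2O[C@]1(C)n1c3ccccc3c3c4c(c5c6cc(Br)ccc6n2c5c31)C(=O)NC4` gives 960 nM.

Compound 4 `CO[C@@H]1[C@H](N(C)c2ncc(-c3c[nH]c4ccc(Cl)cc34)s2)C[C@H]2O[C@]1(C)n1c3ccccc3c3c4c(c5c6cc(Br)ccc6n2c5c31)C(=O)NC4` is not yet measured in this assay. It differs from compound 3 by chloro in place of fluoro on an aromatic carbon. The same change was made once before, from compound 1 to compound 2: chloro in place of fluoro on an aromatic carbon, and there it gave a 1.8-fold higher number from compound 1 to compound 2 (0.27 log units; within the scatter). The two cores differ as well: bromo in place of chloro on an aromatic carbon, which gave a 3.0-fold higher number from compound 1 to compound 3 (0.48 log units; beyond the scatter). The place of the change is the same in both pairs, and because a 1.8-fold higher number from compound 1 to compound 2 (0.27 log units; within the scatter) stayed within the scatter, a step of similar size is expected for compound 4. Compound 4 is therefore estimated to give 1600 nM in this assay, an expected step of a 1.7-fold higher number from compound 3 to compound 4 (0.22 log units; within the scatter). For compound 4 the expected range runs from 700 nM to 3600 nM.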

Compound 4, half-maximal inhibitory concentration: 700 nM
The estimate for compound 4 lay 2.3-fold (0.36 log units) above the measured number; measured number inside the range.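

In this assay, chloro in place of fluoro gave a 1.4-fold lower number from compound 3 to compound 4 (0.14 log units; within the scatter), and this cannot be told apart from the same change on the other core: the same change on two cores in this assay, a 1.8-fold higher number (0.27 log units; within the scatter) from compound 1 to compound 2 and a 1.4-fold lower number (0.14 log units; within the scatter) from compound 3 to compound 4, 2.5-fold (0.40 log units) apart, within the scatter of two such steps. Bromo in place of chloro gave a 1.2-fold higher number from compound 2 to compound 4 (0.07 log units; within the scatter), and this too cannot be told apart from its earlier counterpart: the same change on two cores in this assay, a 3.0-fold higher number (0.48 log units; beyond the scatter) from compound 1 to compound 3 and a 1.2-fold higher number (0.07 log units; within the scatter) from compound 2 to compound 4, 2.5-fold (0.40 log units) apart, within the scatter of two such steps. Within the data shown here, the two pairs give no sign that either change acts differently from one core to the other, but they do not show that its effect carries over, since each change was seen on only two cores and most of the steps stayed within the scatter.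

The compounds shown leave open what a nitrile or a methoxy group would do in place of the halogen on the indole. They also leave open how an iodo group or a hydrogen would compare with the chloro and bromo groups on the core.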